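The source may hold more compounds than are shown below. What is called first, only, known or untested is meant among the compounds shown, and "the series" means these compounds.

Working notes on the series of phenethylthiomethyl compounds.

Compound 1 `Cc1cc(-c2cccc(O)c2)c2ncc(CSCCc3ccccc3)n2c1` carries a 3-hydroxyphenyl group and in an ADME assay on HEL cells (Homo sapiens) for cytotoxicity, with a stated time of 3 days (on this read-out lower numbers stand for higher toxicity in this test and higher numbers for lower toxicity in this test), compound 1 gives 20 ug/mL. Compound 2 `Cc1cc(-c2cccc(F)c2)c2ncc(CSCCc3ccccc3)n2c1` is the fluoro analogue, and in this assay compound 2 gives 20 ug/mL. The step from compound 1 to compound 2 is no change at the digits printed from compound 1 to compound 2 (within the scatter), so exchanging the fluoro for the hydroxy on the aromatic carbon left the read-out where it was.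

Compound 3 `Cc1cc(-c2ccsc2)cn2c(CSCCc3ccccc3)cnc12` bears a thiophen-3-yl group. In this assay compound 3 is known only by a limit, >= 4 ug/mL, which is one of the bounds of the assay rather than a number (the limit of >= 4 ug/mL in this assay, at which 1 of the 3 values shown sits). Where compound 3 stands on the scale relative to compound 1 and compound 2 therefore cannot be fixed from the values shown.

Compound 4 `Cc1cc(-c2cccc(C#N)c2)cn2c(CSCCc3ccccc3)cnc12` is not yet measured. It differs from compound 3 in one place (3-cyanophenyl in place of thiophen-3-yl on an aromatic carbon). Among the compounds with values here, no measured step exchanges one aryl group for another in this position; the single step available, from compound 1 to compound 2, concerns only a substituent on the pendant ring and was within the scatter. On that slim basis, and given the limit of compound 3, the read-out is expected to remain in the range seen for compound 1 and compound 2, with no step beyond the scatter expected: a step that the limit leaves unreadable from compound 3 to compound 4. Compound 4 is thus estimated at 20 ug/mL, between 4 ug/mL and 60 ug/mL.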

Compound 4, minimum cytotoxic concentration: > 100 ug/mL
Compound 4 ended at the assay's limit (the forecaster's own chance of this, stated with the estimate: 40%); middle value at least 5.0-fold (0.69 log units) away from the limit.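

In this assay, within the data shown here, compound 3 and compound 4 are each known only by a limit of the assay, so no step between compound 3 and compound 4 can be read. The compounds shown leave open whether 3-cyanophenyl in place of thiophen-3-yl on the shared core changes the read-out at all, and by how much.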